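TRPV1 antagonists: swapping the furan for a fluorophenethyl chain

The source may hold more compounds than are shown below. What is called first, only, known or untested is meant among the compounds shown, and "the series" means these compounds.

Measured compounds:
compound 1 `CC(C(=O)NCc1ccc(C(F)(F)F)nc1-c1ccc(Cl)cc1)c1ccc(NS(C)(=O)=O)c(F)c1`, 0.7 nM
compound 2 `CC(C(=O)NCc1ccc(C(F)(F)F)nc1-c1ccc(C(C)(C)C)cc1)c1ccc(NS(C)(=O)=O)c(F)c1`, 0.5 nM
compound 3 `CC(C(=O)NCc1ccc(C(F)(F)F)nc1-c1ccco1)c1ccc(NS(C)(=O)=O)c(F)c1`, 5.8 nM

Compound 3 gives the highest number of the three in an assay on CHO cells for antagonist activity at transient receptor potential cation channel subfamily V member 1 (Homo sapiens), read by FLIPR; a higher number here means a weaker inhibitor, a lower number a stronger inhibitor; its nearest neighbour is compound 1, with an 8.3-fold higher number from compound 1 to compound 3 (0.92 log units; beyond the scatter), and compound 2 lies further off, with a 12-fold higher number from compound 2 to compound 3 (1.06 log units; beyond the scatter). Compound 4 `CC(C(=O)NCc1ccc(C(F)(F)F)nc1CCc1ccc(F)cc1)c1ccc(NS(C)(=O)=O)c(F)c1` differs from compound 3 in one place: 2-(4-fluorophenyl)ethyl in place of furan-2-yl on an aromatic carbon. Both measured steps onto the furan-2-yl weakened inhibition, and compound 4 brings back a six-membered carbon ring, now carried on a two-carbon chain. Within the data shown here, no measured step shows such a chain, so the expected effect is drawn from compounds 1 and 2 only: compound 4 is expected to move to a lower number, by about a 1.9-fold lower number from compound 3 to compound 4 (0.29 log units; within the scatter), giving an estimate of 3 nM with a range from 0.8 nM to 12 nM.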

Compound 4, inhibition constant: 1.8 nM
Compound 4: the middle estimate sits 1.7-fold (0.22 log units) above what was measured, and the stated range covers the measured number.
By their numbers in this assay, from the lowest: compounds 2 and 1 (each within the scatter of the next); then compound 4; then compound 3.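

At this place, next to the ring nitrogen, the six-membered aromatic ring need not be attached directly: 2-(4-fluorophenyl)ethyl regains part of the ground lost with furan-2-yl in this assay (a 3.2-fold lower number from compound 3 to compound 4 (0.51 log units; beyond the scatter)). It still falls short of both directly attached rings, 4-(tert-butyl)phenyl (a 3.6-fold higher number from compound 2 to compound 4 (0.56 log units; beyond the scatter)) and 4-chlorophenyl (a 2.6-fold higher number from compound 1 to compound 4 (0.41 log units; beyond the scatter)). Nothing available explains these differences. The compounds shown do not separate the contribution of the chain from that of its fluorine. A plain 2-phenylethyl group, a longer chain such as 3-(4-fluorophenyl)propyl, or an amine at this place would address that question.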